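The source may hold more compounds than are shown below. What is called first, only, known or untested is meant among the compounds shown, and "the series" means these compounds.

Among the measured compounds shown here, in a functional assay on DU-145 cells (Homo sapiens) for inhibition, read by trypan blue exclusion, with a stated time of 96 h (on this read-out lower numbers stand for stronger inhibition of growth and higher numbers for weaker inhibition of growth), compound 2 (`CCOc1ccc(/C=C(\C(=O)c2ccc(Cl)cc2)S(=O)(=O)c2ccc(C)cc2)cc1OC`) gives 1000 nM and holds the lower of the two numbers so far, while compound 1 (`CCOc1ccc(/C=C(/SCc2ccc(Cl)c(Cl)c2)C(=O)c2ccc(Cl)cc2)cc1OC`) gives 25000 nM as the higher one. The unmeasured compound 3 (`CCOc1ccc(/C=C(/SCc2ccc(F)cc2)C(=O)c2ccc(Cl)cc2)cc1OC`) brings (4-fluorobenzyl)sulfanyl in place of (4-methylphenyl)sulfonyl on a double-bonded chain carbon bound to a carbonyl carbon and a double-bonded chain carbon in a single swap: (4-fluorobenzyl)sulfanyl in place of (4-methylphenyl)sulfonyl on a double-bonded chain carbon bound to a carbonyl carbon and a double-bonded chain carbon. For the measured compounds named here, the one measured step that bears on this is a 25-fold lower number from compound 1 to compound 2 (1.40 log units; beyond the scatter) for the opposite kind of swap, large and beyond the scatter, although compound 1 carries (3,4-dichlorobenzyl)sulfanyl instead. In this assay a large rise is therefore expected, with a 15-fold higher number from compound 2 to compound 3 (1.18 log units; beyond the scatter) as the estimated step. Compound 3 is estimated at 15000 nM (expected range 4000 nM to 50000 nM).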

Compound 3, concentration for 50% growth inhibition: 1000 nM
The estimate for compound 3 lay 15-fold (1.18 log units) above the measured number; measured number below the stated range.
By their numbers in this assay, from the lowest: compounds 2 and 3 (each within the scatter of the next); then compound 1.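

In this assay, the sulfonyl group is not required at this position: swapping (4-methylphenyl)sulfonyl for (4-fluorobenzyl)sulfanyl gives no change at the digits printed from compound 2 to compound 3 (within the scatter). Among the sulfanyl compounds, the ring decides the outcome, as 4-fluorophenyl in place of 3,4-dichlorophenyl gives a 25-fold lower number from compound 1 to compound 3 (1.40 log units; beyond the scatter), so the weak result of compound 1 does not belong to the sulfanyl link as such. Nothing available explains either result.

From the compounds shown here alone, it remains open whether a plain benzyl or a 4-chlorobenzyl group would match the 4-fluorobenzyl group. The effect of an amine on that ring is also unknown.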